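The source may report more compounds than this note shows. Statements on the series, on what has been measured and on what is new or still open speak of the compounds shown alone.

In a functional assay on C8166 cells (Homo sapiens) for cytotoxicity, read by MTT assay (a higher number here means that more compound is tolerated, a lower number that less compound is tolerated), compound 1 `Cc1ccc(C(=O)Nc2cc(Cl)ccc2OCC(=O)Nc2ccc(S(N)(=O)=O)cc2C)cc1C` gives 84100 nM and compound 2 `Cc1cc(S(N)(=O)=O)ccc1NC(=O)COc1ccc(Cl)cc1NC(=O)c1ccc(Cl)c(Cl)c1` gives 158000 nM. Going by the values given here, compound 2 thus stands level with compound 1, the only other measured compound, since the two values lie within the scatter of each other. Compound 3 `Cc1cc(S(N)(=O)=O)ccc1NC(=O)COc1ccc(Cl)cc1NC(=O)/C=C/c1ccccc1` keeps the shared core and changes one group: 2-phenylethenyl in place of 3,4-dichlorophenyl on a carbonyl carbon. Among the compounds with values here, one measured step bears on this place, a 1.9-fold higher number from compound 1 to compound 2 (0.27 log units; within the scatter), and it exchanged one substituted phenyl group for another without leaving the scatter. Neither measured compound carries a 2-phenylethenyl group, so this evidence is thin. On the strength of that single small step, no change beyond the scatter is expected, and the estimate amounts to a 1.4-fold lower number from compound 2 to compound 3 (0.14 log units; within the scatter). For compound 3 the expected value is 115000 nM, with an estimated range from 45000 nM to 280000 nM.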

Compound 3, half-maximal cytotoxic concentration: 163000 nM
Compound 3: the middle estimate sits 1.4-fold (0.15 log units) below what was measured; low and high end bracket the measured number.
By their numbers in this assay, from the lowest: compounds 1, 2 and 3 (each within the scatter of the next).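

In this assay, 2-phenylethenyl in place of 3,4-dichlorophenyl on the carbonyl carbon gives a 1.0-fold higher number from compound 2 to compound 3 (0.01 log units; within the scatter) and, in place of 3,4-dimethylphenyl, it gives a 1.9-fold higher number from compound 1 to compound 3 (0.29 log units; within the scatter) at the same position. Going by these compounds alone, this position, until now seen only with substituted phenyl groups, thus also holds a group with a double bond outside the aromatic ring, and all three compounds stay within the scatter of one another. No measurement at hand says why the number holds across these groups. From the compounds shown here alone, all three groups carry a six-membered aromatic ring of carbon only, so it remains open whether an amine, a carboxylic acid or a saturated alkyl chain on this carbonyl carbon would move the number beyond the scatter. Going by these compounds, it also remains open whether a change elsewhere on the shared core would do so.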